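The source may report more compounds than this note shows. Statements on the series, on what has been measured and on what is new or still open speak of the compounds shown alone.

Working notes on the amide-side chain of this series. Compound 1 `NCCNC(=O)Cn1nc(N)c2c(C(F)(F)F)cc(-c3ccccc3)nc21` gives 42900 nM in a functional assay on MCF7 cells (Homo sapiens) for cytotoxicity, read by MTT assay, with a stated time of 24 h; a higher number here means a weaker inhibitor, a lower number a stronger inhibitor. Compound 2 `Nc1nn(CC(=O)NCCO)c2nc(-c3ccccc3)cc(C(F)(F)F)c12` gives 78200 nM in this assay and stands with the highest number of the three measured; its nearest neighbour is compound 1, the difference being a 1.8-fold higher number from compound 1 to compound 2 (0.26 log units; within the scatter), and the furthest is compound 3 `Nc1nn(CC(=O)N2CCCCC2)c2nc(-c3ccccc3)cc(C(F)(F)F)c12`, which gives 4100 nM in this assay, the step being a 19-fold lower number from compound 2 to compound 3 (1.28 log units; beyond the scatter).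

Compound 4 `Nc1nn(CC(=O)NCC(=O)O)c2nc(-c3ccccc3)cc(C(F)(F)F)c12` differs from compound 2 as follows: carboxy in place of hydroxymethyl on a saturated chain carbon bound to an amide-type nitrogen. Of the measured steps, the one that bears most directly is the change of a terminal group on the same chain, a 1.8-fold higher number from compound 1 to compound 2 (0.26 log units; within the scatter), which was within the scatter. The two large steps, a 10-fold lower number from compound 1 to compound 3 (1.02 log units; beyond the scatter) and a 19-fold lower number from compound 2 to compound 3 (1.28 log units; beyond the scatter), both involve exchanging the open chain for piperidin-1-yl on the carbonyl carbon and so describe a different kind of change from the one taken here. Going by the values given here, no step in the set pairs an acid-bearing chain with any other, so the expectation rests on the one exchange of chain terminus seen. A step of no more than the scatter is expected from compound 2 to compound 4, a 1.2-fold higher number from compound 2 to compound 4 (0.06 log units; within the scatter), with the number staying at the weak end of the series. Compound 4 is therefore estimated at 90000 nM in this assay, within a range from 35000 nM to 250000 nM.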

Compound 4, half-maximal inhibitory concentration: 21200 nM
Compound 4: the middle estimate sits 4.2-fold (0.63 log units) above what was measured, and the stated range ends above it.
By their numbers in this assay, from the lowest: compound 3; then compound 4; then compounds 1 and 2 (each within the scatter of the next).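

Going by these compounds alone, the terminus of the open chain proves able to move the number in this assay: carboxy in place of hydroxymethyl on a saturated chain carbon bound to an amide-type nitrogen gives (a 3.7-fold lower number from compound 2 to compound 4 (0.57 log units; beyond the scatter)), and carboxy in place of aminomethyl at the same place gives (a 2.0-fold lower number from compound 1 to compound 4 (0.31 log units; beyond the scatter)), whereas the only terminal exchange seen earlier, hydroxy in place of amino (a 1.8-fold higher number from compound 1 to compound 2 (0.26 log units; within the scatter)), stayed within the scatter. Even so, the carboxy-ended chain does not close the gap to the piperidin-1-yl amide, with (carboxymethyl)amino in place of piperidin-1-yl on the carbonyl carbon giving (a 5.2-fold higher number from compound 3 to compound 4 (0.71 log units; beyond the scatter)), so compound 3 keeps the lowest number of the four. No measurement in hand bears on why the carboxy terminus gives a lower number than the hydroxymethyl or aminomethyl termini.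

Open, as far as these compounds go, is whether the lower number stays with a methyl ester in place of carboxy, or with a longer chain ending in a carboxylic acid. Also open, from the compounds shown here alone, is whether a carboxy group carried on the piperidine ring would give a number closer to compound 3 or to compound 4.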